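One Methyl Less on the Acyl Chain

The compounds below may be only part of what the source reports. "The series", "measured", "known", "first", "only" and "open" are said of these compounds alone.

Measured compounds in an assay on HEK293 cells for positive allosteric modulation of metabotropic glutamate receptor 2 (Rattus norvegicus), read by thallium flux, with a stated time of 2.5 min; on this read-out higher numbers stand for larger maximal responses and lower numbers for smaller maximal responses:
compound 1, `Cc1cc(C(=O)O)ccc1OCCCCOc1ccc(C(=O)CC(C)C)c(O)c1C`, gives 83.9%;
compound 2, `Cc1c(OCCCCOc2ccc(C(=O)C(C)C)c(O)c2C)cccc1C(=O)O`, gives 66.9%;
compound 3, `CCCC(=O)c1ccc(OCCCCOc2ccc(C(=O)O)cc2C)c(C)c1O`, gives 79.3%.

Compound 1 and compound 3 differ in one place: hydrogen in place of methyl on a saturated chain carbon bound to two saturated chain carbons. This change gives a number 4.6 percentage points lower from compound 1 to compound 3 (within the scatter). Compound 2 shows the lowest of the three numbers. The core of compound 2 differs from the core of compound 1 in more than one place, and that difference is not broken down here.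

Compound 4, `CCC(=O)c1ccc(OCCCCOc2cccc(C(=O)O)c2C)c(C)c1O`, has not yet been measured in this assay. It is related to compound 2 by the same kind of change: hydrogen in place of methyl on a saturated chain carbon bound to a carbonyl carbon and a saturated chain carbon. The surroundings differ: here the methyl leaves a saturated chain carbon bound to a carbonyl carbon and a saturated chain carbon, whereas in compound 1 it left a saturated chain carbon bound to two saturated chain carbons. The expectation for compound 4 rests on the earlier step, which stayed within the scatter, a number 4.6 percentage points lower from compound 1 to compound 3 (within the scatter). For compound 4 the expected step is therefore small, a number 3.9 percentage points lower from compound 2 to compound 4 (within the scatter). Compound 4 is thus estimated at 63%, with a likely range from 50% to 76%.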

Compound 4, largest response reached (reported as percent of maximum), in percent of the reference or control that the assay uses: 71.3%
Compound 4: the middle estimate sits 8.3 percentage points below what was measured, within the range that was stated.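

In this assay, the change from isopropyl to ethyl, which is also isopropylcarbonyl to propanoyl, gives a number 4.4 percentage points higher from compound 2 to compound 4 (within the scatter). Removing this methyl from the acyl chain thus left the maximal response within the usual scatter on both cores, and the two steps do not differ from each other beyond what repeated measurement would produce: the same change on two cores in this assay, a number 4.6 percentage points lower (within the scatter) from compound 1 to compound 3 and a number 4.4 percentage points higher (within the scatter) from compound 2 to compound 4, 9 percentage points apart, within the scatter of two such steps This shows that, for these two pairs, the small size of the step carried over from one core to the other, but it does not establish a direction for the change, nor does it show that the step would stay small on any further core.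

The compounds shown leave open how a longer chain or a cyclopropyl group on the carbonyl would read out in this assay. They also leave open what would happen if an amide or a tetrazole took the place of the carboxylic acid that all of them carry.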